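This account rests on a few compounds, and the source may have more. Where it says the series, first, only, none or still open, it means among the compounds named here.

Measured compounds:
- compound 1, `CC(C)(C)c1cnc(CCc2ccc(-c3ccccc3C(=O)O)cc2)[nH]1`: 4330 nM
- compound 2, `CCCCc1cnc(C(Cc2ccc(-c3ccccc3C(=O)O)cc2)C(C)C)[nH]1`: 4620 nM
- compound 3, `CCCCc1cnc(/C=C/c2ccc(-c3ccccc3C(=O)O)cc2)[nH]1`: 4380 nM

All three share the same core and were run in an in vitro functional assay on cells for agonist activity at Bombesin receptor subtype-3 (Homo sapiens), read by luminescence and calcium flux; a lower number here means that less compound is needed, a higher number that more compound is needed for the effect. Compound 1 gives 4330 nM, the lowest of the three numbers, but the gap to compound 3 and to compound 2 falls within the usual scatter of repeated measurements, so no order among the three can be read from these values. Going by the values given here, the series so far is flat: a butyl in place of tert-butyl, a branched linker or an unsaturated linker all return essentially the same reading in this assay.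

Compound 4, `CCC(C)(CC)Cc1cnc(CCc2ccc(-c3ccccc3C(=O)O)cc2)[nH]1`, has not yet been measured. Its change from compound 1 is:

2-ethyl-2-methylbutyl in place of tert-butyl on an aromatic carbon

Among the compounds with values here, the only comparison that speaks to the weight of the alkyl group on the five-membered ring is compound 1 against compound 2 and compound 3, whose values sit together. Nothing in the measured set shows a shift when the group on that ring is enlarged, so the step of a 1.1-fold lower number from compound 1 to compound 4 (0.03 log units; within the scatter) is expected to stay within the scatter, with no direction favoured. Compound 4 is therefore estimated at 4000 nM in this assay, with a range of 1500 nM to 11000 nM.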

Compound 4, half-maximal effective concentration: 76 nM
The estimate for compound 4 lay 53-fold (1.72 log units) above the measured number; the measured number lies below the stated range.
By their numbers in this assay, from the lowest: compound 4; then compounds 1, 3 and 2 (each within the scatter of the next).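

In this assay, the position on the aromatic carbon of the five-membered ring with 2 nitrogen proves highly responsive to the alkyl group it carries: the step of a 57-fold lower number from compound 1 to compound 4 (1.76 log units; beyond the scatter) comes from 2-ethyl-2-methylbutyl in place of tert-butyl, with the rest of the shared core unchanged. Going by these compounds alone, compounds 2 and 3 differ from compound 1 in more than one place, so they could not isolate this position, and only the pair of compound 1 and compound 4 now does so. Both groups are all carbon, with no ring, no hydrogen-bond donors or acceptors and no net charge, and no measurement at hand accounts for the size of the step.

The compounds shown leave open whether the lower number follows the length of the chain, its branching or its bulk, which a straight hexyl chain, a neopentyl group or a cyclohexylmethyl group on the same carbon would help to separate. They also leave open whether the step carries over to the unsaturated or branched linkers, and whether the carboxylic acid can give way to an amide or a tetrazole alongside 2-ethyl-2-methylbutyl.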